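Swapping 1H-benzimidazol-2-yl for pyrimidin-2-yl: an expected stability

A few compounds are considered here, and "the series" means these few. Any claim that something is new, unique, unknown or untested is made for them only; others in the source may bear on it.

Measured in an ADME assay on microsomes from liver (Homo sapiens) for metabolic stability, read by LC-MS, with a stated time of 10 min, tested at 0.5 uM; a lower number here means that less of the compound is left, a higher number that more of the compound is left:
Compound 1 `c1ccc2c(c1)CN[C@@H](CN(CCCN1CCNCC1)[C@H]1CCCc3cccnc31)C2`: 100%
Compound 2 `c1cnc2c(c1)CCC[C@@H]2N(CCCN1CCNCC1)Cc1nc2ccccc2[nH]1`: 63%

Compound 2 stands lower of the two, and the gap to compound 1 is beyond the usual scatter. The unmeasured compound 3 `c1cnc(CN(CCCN2CCNCC2)[C@H]2CCCc3cccnc32)nc1` differs from compound 2 in one place, on a saturated chain carbon bound to an amine nitrogen: pyrimidin-2-yl in place of 1H-benzimidazol-2-yl on a saturated chain carbon bound to an amine nitrogen. Among the compounds with values here, the one measured step at this place is a number 37 percentage points lower from compound 1 to compound 2 (beyond the scatter). That large step did not involve pyrimidin-2-yl, so it is only a rough guide. With 1H-benzimidazol-2-yl gone, a partial return towards compound 1 at 100% is expected in this assay, though the data cannot confirm this direction. The expected size is moderate: a number 17 percentage points higher from compound 2 to compound 3 (beyond the scatter). The estimate for compound 3 is 80%, with an expected range from 60% to 98%.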

Compound 3, percent of the compound remaining: 100%
The estimate for compound 3 lay 20 percentage points below the measured number, outside the stated range (above it).
By their numbers in this assay, from the lowest: compound 2; then compounds 1 and 3 (each within the scatter of the next).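

In this assay, pyrimidin-2-yl on the saturated chain carbon bound to an amine nitrogen gives a number 37 percentage points higher from compound 2 to compound 3 (beyond the scatter), so among the three groups shown at this place, only 1H-benzimidazol-2-yl goes with a lower number. The comparison with the other group gives no change at the digits printed from compound 1 to compound 3 (within the scatter), which means that 1,2,3,4-tetrahydroisoquinolin-3-yl and pyrimidin-2-yl cannot be told apart here, even though they are different groups. No measurement shown explains the lower number for compound 2.

On these data alone, it remains open whether that lower number follows the six-membered carbon ring or the hydrogen-bond donor of 1H-benzimidazol-2-yl. A 1H-imidazol-2-yl group, which has the ring nitrogen-hydrogen without the carbon ring, and a benzoxazol-2-yl group, which has the carbon ring without that hydrogen, could separate the two.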